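The compounds below may be only part of what the source reports. "The series", "measured", "known", "first", "only" and "open" are said of these compounds alone.

Measured so far:
Compound 1 `COc1cc(-c2cc(/C=C/C(=O)c3ccc(N)cc3)[nH]n2)cc(OC)c1OC` — in a functional assay on LOX IMVI cells (Homo sapiens) for cytotoxicity, read by sulforhodamine B assay, with a stated time of 48 h, tested at 0.01 uM (a lower number here means a stronger effect, a higher number a weaker effect of the compound at the concentration tested), compound 1 gives 98%.
Compound 2 `COc1ccc(C(=O)/C=C/c2cc(-c3cc(OC)c(OC)c(OC)c3)n[nH]2)cc1` — compound 2 gives 95%.
Compound 3 `COc1cc(-c2cc(/C=C/C(=O)c3ccc(F)c(F)c3)[nH]n2)cc(OC)c1OC` — compound 3 gives 93%.

Compound 1 holds the highest number of the three, but the gaps are small: a number 3 percentage points lower from compound 1 to compound 2 (within the scatter) and a number 5 percentage points lower from compound 1 to compound 3 (within the scatter), both within the scatter, as is a number 2 percentage points lower from compound 2 to compound 3 (within the scatter). No order among the three is claimed.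

Compound 4 `COc1ccc(-c2cc(/C=C/C(=O)c3ccc(N)cc3)[nH]n2)cc1OC` differs from compound 1 in one place: hydrogen in place of methoxy on an aromatic carbon.

For the measured compounds named here, none of the measured steps touches this position; all three exchange the group on the carbonyl carbon, and each stayed within the scatter. Going by the values given here, there is therefore no measured step that bears directly on the change, and no basis for expecting a step beyond the scatter in this assay in either direction.

Compound 4 is accordingly estimated at 95%, with a range from 80% to 105%, an expected step of a number 3 percentage points lower from compound 1 to compound 4 (within the scatter).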

Compound 4, a percentage reported as activity, at one concentration (the size of the read-out at that concentration, not a potency): 100%
Compound 4: middle estimate off by 5 percentage points, on the low side; the measured number falls inside the stated range.
By their numbers in this assay, from the lowest: compounds 3, 2, 1 and 4 (each within the scatter of the next).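

Hydrogen in place of methoxy on an aromatic carbon, ortho to a methoxy group, is the only change shown away from the carbonyl side, and in this assay it gives a number 2 percentage points higher from compound 1 to compound 4 (within the scatter). This position, like the group on the carbonyl carbon, therefore shows no step beyond the scatter at this one concentration. No measurement on hand gives a reason for this step.

Going by these compounds, whether a larger group at this position, such as ethoxy or an amine, would give a step beyond the scatter stays open. So does the effect of removing the other methoxy groups.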